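A few compounds are considered here, and "the series" means these few. Any claim that something is new, unique, unknown or untested is made for them only; others in the source may bear on it.

The measured compounds:
compound 1, `O=c1c(CSC(=S)N2CCN(c3ccccc3)CC2)coc2ccccc12`: 2900 nM
compound 2, `CN1CCN(C(=S)SCc2coc3ccccc3c2=O)CC1`: 17600 nM
compound 3, `O=c1c(SC(=S)N2CCCCC2)coc2ccc(Cl)cc12`: > 25000 nM

In a functional assay on LM7 cells (Homo sapiens) for antiproliferative activity, read by MTT assay, with a stated time of 72 h (a lower number here means a stronger inhibitor, a higher number a weaker inhibitor), compound 1 gives 2900 nM and compound 2 gives 17600 nM. For compound 3 this assay reports only a limit, > 25000 nM, a case of the limit of > 25000 nM in this assay, at which 1 of the 3 values shown sits. Compound 2 therefore stands with the higher of the two numbers reported; its nearest neighbour is compound 1, and the step of a 6.1-fold higher number from compound 1 to compound 2 (0.78 log units; beyond the scatter) lies beyond the scatter.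

Compound 4, `O=c1c(CSC(=S)N2CCCCC2)coc2ccccc12`, has not been measured. It differs from compound 2 by piperidin-1-yl in place of 4-methylpiperazin-1-yl on a thiocarbonyl carbon. For the measured compounds named here, the only measured step, a 6.1-fold higher number from compound 1 to compound 2 (0.78 log units; beyond the scatter), concerns a methyl against a phenyl on the amine nitrogen of the ring and does not bear directly on replacing the whole 4-methylpiperazin-1-yl by piperidin-1-yl. Compound 3 also carries piperidin-1-yl, but it differs from compound 4 in more than one place, so its limit is only weak guidance. Going by the values given here, with no directly comparable step, a change in this assay of modest size at most is expected, in either direction. Compound 4 is estimated at 9000 nM, between 2500 nM and 25000 nM, which means an expected step of a 2.0-fold lower number from compound 2 to compound 4 (0.29 log units; within the scatter).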

Compound 4, half-maximal inhibitory concentration: 4600 nM
Compound 4: middle estimate off by 2.0-fold (0.29 log units), on the high side, within the range that was stated.
By their numbers in this assay, from the lowest: compounds 1 and 4 (each within the scatter of the next); then compound 2. At a limit, above all of these: compound 3.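

In this assay, the ring on the thiocarbonyl carbon now has a second measured change, a 3.8-fold lower number from compound 2 to compound 4 (0.58 log units; beyond the scatter), with piperidin-1-yl in place of 4-methylpiperazin-1-yl. Compound 1 gives 2900 nM and compound 4 gives 4600 nM, values within the scatter of each other, so a ring with a single hetero atom serves as well here as the phenyl-bearing piperazine, and of the three only compound 2 stands apart. Nothing measured here gives a reason for this step.

The compounds shown leave open how a morpholine ring, an unsubstituted piperazine or an open-chain diethylamino group would fare on the thiocarbonyl carbon. Compound 3 gives only a limit, > 25000 nM, and differs from compound 4 in more than one place, so the two cannot be compared.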